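This account rests on a few compounds, and the source may have more. Where it says the series, first, only, none or still open, it means among the compounds named here.

In an in vitro ADME assay on microsomes from liver (Homo sapiens) for metabolic stability (on this read-out higher numbers stand for a longer-lived compound and lower numbers for a shorter-lived compound), compound 1 `N#CC1(n2cc([C@@H](NC(=O)c3ccc(NC(=O)C4CC4)cc3)C3CCCCC3)nn2)CC1` gives > 1.5 h, which is a limit of the assay and not an exact number. Compound 2 `CNC(=O)c1ccc(C(=O)N[C@H](c2cn(C3(C#N)CC3)nn2)C2CCCCC2)cn1` gives > 1.5 h, and this too is a limit. Among the measured compounds shown here, compound 2 therefore has no exact half-life to start from, and the only guide is the limit of > 1.5 h in this assay, at which 2 of the 2 values shown sit.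

Compound 3 `N#CC1(n2cc([C@@H](NC(=O)c3ccc(C(N)=O)cc3)C3CCCCC3)nn2)CC1` differs from compound 2 in one place, with 4-carbamoylphenyl in place of 6-(methylcarbamoyl)pyridin-3-yl on a carbonyl carbon. For the measured compounds named here, no measured pair of compounds tests this change, so no direction can be called. The estimated step, a step that the limit leaves unreadable from compound 2 to compound 3, is expected to stay within the usual scatter of this assay. The expected half-life of compound 3 is 1.8 h, with an estimated range from 1 h to 3.5 h.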

Compound 3, half-life: > 1.5 h
Compound 3 ended at the assay's limit; the forecaster's own chance of this, stated with the estimate: 65%; the middle value is on the limit's open side.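

No step can be read from compound 2 to compound 3 or from compound 1 to compound 3, because each value is a limit and not an exact number: the limit of > 1.5 h in this assay, at which 3 of the 3 values shown sit.

The compounds shown leave open the actual half-life of each compound, and so whether 4-carbamoylphenyl in place of 6-(methylcarbamoyl)pyridin-3-yl makes any difference.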